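The source may report more compounds than this note shows. Statements on the series, on what has been measured and on what is new or still open speak of the compounds shown alone.

Measured compounds:
Compound 1, `O=C(/C=C1\CCc2c(F)cc(F)cc21)NC1CC1`: in a functional assay on the whole organism with Rattus norvegicus as the target, at a dose of 20 mg/kg by the oral route (on this read-out higher numbers stand for more inhibition at the one dose given (going by the name of the read-out) and lower numbers for less inhibition), compound 1 gives 28%.
Compound 2, `CCN(C)C(=O)/C=C1\CCc2ccc(F)cc21`: in this assay compound 2 gives 44%.

Of the two numbers shown, compound 2 stands highest; its nearest neighbour is compound 1, whose value lies lower by a gap beyond the usual scatter. The two measured compounds differ in more than one place, so nothing can be said of either change on its own; only the two values themselves are known.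

Compound 3, `O=C(/C=C1\CCc2ccc(F)cc21)NC1CC1`, has not yet been measured in this assay. It differs from compound 2 in one place: cyclopropylamino in place of ethyl(methyl)amino on a carbonyl carbon. The amide of compound 3 is thus the same as that of compound 1, while its core is that of compound 2. Because compound 1, which carries the same cyclopropylamino, gives 28%, compound 3 is expected to fall between the two measured values, with a step of a number 10 percentage points lower from compound 2 to compound 3 (within the scatter) that is modest and downward, near the edge of the scatter. Compound 3 is therefore estimated at 34%, within a range from 16% to 54%.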

Compound 3, a percentage reported as inhibition, in the whole organism at one dose (the size of the read-out at that dose, not a potency): 7%
Beside the measured number, compound 3's estimate is 27 percentage points above it; the measured number lies below the stated range.
By their numbers in this assay, from the lowest: compound 3; then compound 1; then compound 2.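

In this assay, the change of cyclopropylamino for ethyl(methyl)amino on a carbonyl carbon can now be read on its own, and it gives a number 37 percentage points lower from compound 2 to compound 3 (beyond the scatter): the number of heavy atoms stays the same, while the entering group brings a three-membered ring and a hydrogen-bond donor that the leaving group lacks. With cyclopropylamino held fixed, hydrogen in place of fluoro on an aromatic carbon also has a step of its own, a number 21 percentage points lower from compound 1 to compound 3 (beyond the scatter), so at this amide the additional fluoro of compound 1 goes with the higher number. Both steps lie beyond the usual scatter, but nothing available explains either of them.

The compounds shown leave open whether the step at the amide follows the ring or the amide hydrogen, since the two enter together; cyclopropyl(methyl)amino or a plain ethylamino on the same carbonyl carbon would separate them. They also leave open whether the step at the aromatic carbon would hold with ethyl(methyl)amino on the carbonyl carbon, and what a chloro group or a methoxy group there would give.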